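The source may hold more compounds than are shown below. What is called first, only, known or untested is meant among the compounds shown, and "the series" means these compounds.

Measured compounds:
Compound 1 `Cc1nsc2[nH]cnc12` gives 20000 nM.
Compound 2 `CSc1nc2c(C)nsc2[nH]1` gives 60000 nM.
Compound 3 `Cc1nsc2c1ncn2[C@@H]1O[C@H](CO)[C@@H](O)[C@@H]1O` gives only a limit, > 100000 nM.

The three compounds were tested in a functional assay on KB cells (Homo sapiens) for antiproliferative activity; on this read-out lower numbers stand for stronger inhibition and higher numbers for weaker inhibition. Compound 1 and compound 2 differ in one place: methylsulfanyl in place of hydrogen on an aromatic carbon. That change produced a 3.0-fold higher number from compound 1 to compound 2 (0.48 log units; beyond the scatter), so the methylsulfanyl compound shows the weaker inhibition of the two. For compound 3 the result is a limit and not a number (the limit of > 100000 nM in this assay, at which 1 of the 3 values shown sits). The difference between the core of compound 3 and the core of compound 1 is not broken down here.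

Compound 4 `CSc1nc2c(C)nsc2n1[C@@H]1O[C@H](CO)[C@@H](O)[C@@H]1O` has not yet been measured in this assay. It stands to compound 3 as compound 2 stands to compound 1: methylsulfanyl in place of hydrogen on an aromatic carbon. The surroundings of the place are not identical, since in compound 4 the aromatic carbon is also next to the ring atom that bears a group of 9 heavy atoms, so this is the same kind of change rather than the same one. Within the data shown here, since compound 3 already sits at the limit of the assay, and the one measured instance of this kind of change, from compound 1 to compound 2, gave a higher number, compound 4 is expected to show no stronger inhibition than compound 3, with an estimated step that the limit leaves unreadable from compound 3 to compound 4. Compound 4 is therefore expected to give about 200000 nM, most likely again reported only as a limit, within a range of 70000 nM to 600000 nM.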

Compound 4, half-maximal inhibitory concentration: > 100000 nM
Compound 4: no number, only a limit (the forecaster's own chance of this, stated with the estimate: 85%); the middle value is on the limit's open side.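

Compound 4, like compound 3, gives only a limit and not a number in this assay, so no step between the two can be read: the limit of > 100000 nM in this assay, at which 2 of the 4 values shown sit.

The compounds shown leave open whether methylsulfanyl in place of hydrogen on an aromatic carbon changes the inhibition at all when going from compound 3 to compound 4, and how far either compound lies beyond that limit.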